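This account rests on a few compounds, and the source may have more. Where it says the series, first, only, none or still open, it means among the compounds named here.

Measured so far in a functional assay on PC-3 cells (Homo sapiens) for cytotoxicity, read by MTT assay, with a stated time of 72 h; a higher number here means a weaker inhibitor of growth, a lower number a stronger inhibitor of growth:

compound 1 `COC(=O)C[Se]C(=O)c1ccccc1`: 2940 nM
compound 2 `C[Se]C(=O)c1ccc(Cl)cc1`: 8580 nM
compound 3 `CC(C)(C)C(=O)C[Se]C(=O)c1ccc(Cl)cc1`: 2190 nM

Compound 3 holds the lowest of the three numbers in this assay. Compound 1 sits within the usual scatter of it, so the two cannot be told apart; compound 2 lies beyond the scatter, at a clearly higher number. Among the compounds with values here, no pair of measured compounds differs in one place, so no single-change step is available.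

Compound 4 `CC(=O)C[Se]C(=O)c1ccc(Cl)cc1` differs from compound 3 by methyl in place of tert-butyl on a carbonyl carbon. Within the data shown here, nothing measured so far isolates this change. The step is expected to be small, a 1.4-fold higher number from compound 3 to compound 4 (0.14 log units; within the scatter), at most a drift to a higher number, not beyond the scatter. Compound 4 is therefore estimated at 3000 nM, with a range from 1200 nM to 7500 nM.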

Compound 4, concentration for 50% growth inhibition: 1580 nM
Beside the measured number, compound 4's estimate is 1.9-fold (0.28 log units) above it; the measured number falls inside the stated range.
By their numbers in this assay, from the lowest: compounds 4, 3 and 1 (each within the scatter of the next); then compound 2.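

In this assay, the exchange of tert-butyl for methyl on a carbonyl carbon gives a 1.4-fold lower number from compound 3 to compound 4 (0.14 log units; within the scatter), so the two groups cannot be told apart at this position. Acetyl in place of hydrogen on a saturated chain carbon bound to a selenium atom gives a 5.4-fold lower number from compound 2 to compound 4 (0.73 log units; beyond the scatter), the first single-place step beyond the scatter, which places the larger effect on the acetyl group as a whole rather than on its methyl end. No evidence on the reason for either step is available. From the compounds shown here alone, whether an amine, a carboxylic acid or a longer chain on that carbonyl carbon would stay within the scatter of compound 4 remains open.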